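The compounds below may be only part of what the source reports. "The series", "measured", "known", "first", "only" and "open" are said of these compounds alone.

Values in an ADME assay for permeability, using PAMPA, at pH 7.4; on this read-out lower numbers stand for lower permeability and higher numbers for higher permeability:
Compound 1 `Cc1ccc(-c2nc3ccccc3s2)cc1NC(=O)c1cc([N+](=O)[O-])c(N(C)C)cc1Cl`: < 1 10^-6 cm/s (a limit of the assay)
Compound 2 `COC(=O)C1CCN(c2cc(Cl)c(C(=O)Nc3cc(-c4nc5ccccc5s4)ccc3C)cc2[N+](=O)[O-])CC1`: 24 10^-6 cm/s
Compound 3 `Cc1ccc(-c2nc3ccccc3s2)cc1NC(=O)c1cc([N+](=O)[O-])c(N2CCCCC2)cc1Cl`: < 1 10^-6 cm/s (a limit of the assay)

Of these three compounds, only compound 2 has an actual number, 24 10^-6 cm/s. The values of compound 1 and compound 3 are limits of the assay. Compound 4 `COC(=O)C1CCN(c2cc(Cl)c(C(=O)Nc3cc(-c4nc5ccccc5s4)ccc3OC)cc2[N+](=O)[O-])CC1` differs from compound 2 by methoxy in place of methyl on an aromatic carbon, with methoxy in place of methyl on an aromatic carbon. The measured steps were made at another place in the molecule. They are an at least 24-fold higher number from compound 1 to compound 2 (1.38 log units; beyond the scatter) and an at least 24-fold lower number from compound 2 to compound 3 (1.38 log units; beyond the scatter), both large, and a step that the two limits leave unreadable from compound 1 to compound 3, whose size cannot be read. They show that this assay can shift widely across this small set, but none of them measures a change at this carbon. No step beyond the scatter is therefore expected, and the estimate rests on compound 2 at 24 10^-6 cm/s, with a wide margin. The expected change is a 1.2-fold lower number from compound 2 to compound 4 (0.08 log units; within the scatter). For compound 4 the estimated value is 20 10^-6 cm/s, with an expected range from 6 10^-6 cm/s to 45 10^-6 cm/s.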

Compound 4, apparent permeability: < 1 10^-6 cm/s
Compound 4 gave a limit, no number; the forecaster's own chance of this, stated with the estimate: 8%; at least 20-fold (1.30 log units) between middle value and limit.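

In this assay, among the compounds shown here, methoxy in place of methyl on the aromatic carbon para to a 1,3-benzothiazol-2-yl group gives an at least 24-fold lower number from compound 2 to compound 4 (1.38 log units; beyond the scatter) and so shows that this position, which no earlier step touched, can move the read-out as far as the earlier change at another place in the molecule. The 4-(methoxycarbonyl)piperidin-1-yl group is present in both compounds, so in compound 4 it does not by itself keep a readable number. The value of compound 4 is a limit and not a number, and the step gives only a minimum size because compound 4 sits at this limit: the limit of < 1 10^-6 cm/s in this assay, at which 3 of the 4 values shown sit.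

The compounds shown do not tell whether this result is specific to methoxy or would extend to groups such as ethyl, chlorine or hydroxy at this carbon. They also leave open whether a carboxylic acid or an amine in place of methoxycarbonyl would give a number with either methyl or methoxy at this carbon.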